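A Third Methoxy Group Added to Compound 2

This account rests on a few compounds, and the source may have more. Where it says the series, first, only, none or still open, it means among the compounds named here.

Of the compounds shown here, two that share one core have been tested in a functional assay on HOP-92 cells (Homo sapiens) for inhibition, read by sulforhodamine B assay, with a stated time of 48 h; on this read-out higher numbers stand for lower toxicity in this test and lower numbers for higher toxicity in this test. Compound 1, `CCOC(=O)[C@H](CCC(=O)O)NC(=O)c1ccc(CNc2nc3cc(N)cc(N)c3nc2-c2ccccc2)cc1`, reports only a limit of < 100000 nM in this test, so it gives no exact number. That one of the two values sits at a limit is recorded as the limit of < 100000 nM in this assay, at which 1 of the 2 values shown sits. Compound 2, `COc1ccc(CNc2nc3cc(N)cc(N)c3nc2-c2ccccc2)cc1OC`, bears two methoxy groups on its outer ring and gives 66100 nM in this assay; this is the only exact number shown, so compound 2 stands alone as the anchor.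

Compound 3, `COc1cc(CNc2nc3cc(N)cc(N)c3nc2-c2ccccc2)cc(OC)c1OC`, differs from compound 2 in one place: methoxy in place of hydrogen on an aromatic carbon. For the measured compounds named here, no step between two measured compounds is available, so the size of this change cannot be read from the data. Adding a small group of this kind to a ring that already carries two of them is expected to move the reading little, and the step from compound 2 to compound 3 is expected to be a 1.1-fold lower number from compound 2 to compound 3 (0.04 log units; within the scatter), likely within the usual scatter. Compound 3 is therefore estimated at 60000 nM, with a range from 20000 nM to 150000 nM.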

Compound 3, concentration lethal to 50% of the cells: < 50200 nM
Compound 3: only a limit was reported (the forecaster's own chance of this, stated with the estimate: 30%); at least 1.1-fold (0.07 log units) between middle value and limit.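

In this assay, for the compounds shown here, a methoxy group placed on the aromatic carbon ortho to a methoxy group and meta to a large group gives an at least 1.3-fold lower number from compound 2 to compound 3 (0.11 log units; that floor lies within the scatter), which is the first step that can be read at this position of the outer ring. From the compounds shown here alone, compound 3 reports < 50200 nM, and this is a limit and not an exact number, so the step has only a floor and its true size stays unknown because of that limit: the limit of < 50200 nM in this assay, at which 1 of the 3 values shown sits. Going by these compounds alone, since that floor lies within the scatter, no real difference can be claimed yet, and the result shows only that this added methoxy group brings no rise in the number in this test.

No other step can be read from the compounds shown, so one exchange at one position is all there is to go on, and a single step says little about the outer ring as a whole. Going by these compounds, it remains open how the reading would respond to a different group on this same aromatic carbon, such as an amine, a carboxylic acid or a longer chain in place of methoxy.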